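Aryl swap on the triple-bonded carbon: efficacy notes

The compounds below may be only part of what the source reports. "The series", "measured", "known", "first", "only" and "open" are said of these compounds alone.

Three compounds of the series have numbers in an ADME assay on HEK293 cells for agonist activity at metabotropic glutamate receptor 5 (Rattus norvegicus), read by fluorescence and calcium flux; a higher number here means a larger maximal response, a lower number a smaller maximal response. Compound 1 `C[C@@H](NC(=O)c1ccc(C#Cc2ccc(F)cc2)cn1)C(C)(C)O` gives 38.4% in this assay. Compound 2 `Cc1ccccc1C#Cc1ccc(C(=O)N[C@H](C)C(C)(C)O)nc1` gives 24.1%, and compound 3 `C[C@@H](NC(=O)c1ccc(C#Cc2cccnc2)cn1)C(C)(C)O` gives 25.9%. Compound 3 thus stands second highest of the three; its gap to compound 2 is within the scatter, whereas the step of a number 12.5 percentage points lower from compound 1 to compound 3 (beyond the scatter) lies beyond it.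

Compound 4 `C[C@@H](NC(=O)c1ccc(C#Cc2cccc(F)n2)cn1)C(C)(C)O` has not been measured. It differs from compound 3 at one place: 6-fluoropyridin-2-yl in place of pyridin-3-yl on a triple-bonded carbon.

All three measured steps change the group on the triple-bonded carbon, so all bear on this change. The steps of a number 14.3 percentage points lower from compound 1 to compound 2 (beyond the scatter) and a number 12.5 percentage points lower from compound 1 to compound 3 (beyond the scatter) were modest, and the step of a number 1.8 percentage points higher from compound 2 to compound 3 (within the scatter) stayed within the scatter. The step to a fluorinated ring on this carbon has so far given the highest number, so a small rise or no change beyond the scatter is expected in this assay. For compound 4 the estimate is 30%, within 18% to 42%, which means an expected step of a number 4.1 percentage points higher from compound 3 to compound 4 (within the scatter).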

Compound 4, largest response reached (reported as efficacy), in percent of the reference or control that the assay uses: 8.3%
Compound 4: middle estimate off by 21.7 percentage points, on the high side, outside the stated range (below it).
By their numbers in this assay, from the lowest: compound 4; then compounds 2 and 3 (each within the scatter of the next); then compound 1.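

In this assay, going by these compounds alone, the group on the triple-bonded carbon moves the number further than the first three compounds showed, with a number 17.6 percentage points lower from compound 3 to compound 4 (beyond the scatter) and a number 15.8 percentage points lower from compound 2 to compound 4 (beyond the scatter) and, as the only large step so far, a number 30.1 percentage points lower from compound 1 to compound 4 (beyond the scatter) in this series. A fluorine on the ring therefore does not by itself go with a high number, since compound 1 and compound 4 both carry one and stand at opposite ends of the series. Nothing at hand gives a reason for this drop.

From the compounds shown here alone, it remains open whether the fall follows the fluorine or the change from pyridin-3-yl to a pyridin-2-yl ring. The compounds shown do not tell how a plain pyridin-2-yl or a 6-chloropyridin-2-yl would read on this carbon.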